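The source may hold more compounds than are shown below. What is called first, only, known or untested is meant among the compounds shown, and "the series" means these compounds.

Compound 1 `Cc1ccc(-n2nc(-c3ccc4ccccc4c3)nc2N2C(=O)COC23C=CC(=O)C=C3)cc1`: 110 nM
Compound 2 `Cc1ccc(-n2nc(-c3ccc4ccccc4c3)nc2N2C(=O)C(C)OC23C=CC(=O)C=C3)cc1`: 1210 nM
Compound 3 `Cc1ccc(-n2nc(-c3cccc4ccccc34)nc2N2C(=O)COC23C=CC(=O)C=C3)cc1`: 140 nM

For the measured compounds named here, in a functional assay on A549 cells (Homo sapiens) for antiproliferative activity, with a stated time of 5 days (on this read-out lower numbers stand for stronger inhibition and higher numbers for weaker inhibition), compound 1 gives 110 nM, and no compound measured so far lies clearly below it. Changing how the naphthalene is attached gives a 1.3-fold higher number from compound 1 to compound 3 (0.10 log units; within the scatter), while adding a methyl on a saturated ring carbon gives an 11-fold higher number from compound 1 to compound 2 (1.04 log units; beyond the scatter). Compound 4 `O=C1C=CC2(C=C1)OCC(=O)N2c1nc(-c2ccc3ccccc3c2)nn1-c1ccc(C(F)(F)F)cc1` instead has trifluoromethyl in place of methyl on an aromatic carbon. Going by the values given here, no measured step touches this group, so the evidence is indirect. The closest guide is compound 3, also changed on an aromatic carbon, with a 1.3-fold higher number from compound 1 to compound 3 (0.10 log units; within the scatter). The expected step is therefore small, a 1.5-fold higher number from compound 1 to compound 4 (0.16 log units; within the scatter), with no shift beyond the scatter firmly expected. For compound 4 the estimated value is 160 nM, with an expected range of 55 nM to 480 nM.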

Compound 4, half-maximal inhibitory concentration: 460 nM
Beside the measured number, compound 4's estimate is 2.9-fold (0.46 log units) below it; the measured number falls inside the stated range.
By their numbers in this assay, from the lowest: compounds 1 and 3 (each within the scatter of the next); then compound 4; then compound 2.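

For the compounds shown here, the para substituent on the aromatic ring, untouched by the earlier steps, turns out not to be neutral: in this assay trifluoromethyl in place of methyl gives a 4.2-fold higher number from compound 1 to compound 4 (0.62 log units; beyond the scatter), a modest loss. So this site responds to what it carries, unlike the naphthalene attachment, where the one step shown stayed within the scatter. No measurement shown here accounts for this difference.

Still open, on these data alone, is whether hydrogen, chlorine or a methoxy group at this position would match compound 1 or give a lower number.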